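Single dichlorobenzyl ether on the other ring of compound 2

The source may report more compounds than this note shows. Statements on the series, on what has been measured and on what is new or still open speak of the compounds shown alone.

Compound 1 `C=CCc1ccc(O)c(-c2ccc(OCc3ccc(Cl)c(Cl)c3)c(CC=C)c2)c1` gives 17800 nM in a functional assay on CNE2Z cells (Homo sapiens) for inhibition, read by MTT assay, with a stated time of 72 h; on this read-out lower numbers stand for stronger inhibition and higher numbers for weaker inhibition. Compound 3 `C=CCc1ccc(O)c(-c2ccc(OCc3ccc(Cl)cc3Cl)c(CC=C)c2)c1` gives 11300 nM in this assay, and the step of a 1.6-fold lower number from compound 1 to compound 3 (0.20 log units; within the scatter) stays within the scatter. Compound 2 `C=CCc1ccc(OCc2ccc(Cl)c(Cl)c2)c(-c2ccc(OCc3ccc(Cl)c(Cl)c3)c(CC=C)c2)c1` reaches only a limit of this assay, reported as > 50000 nM. Going by these compounds, compound 2 therefore sits at the limit of > 50000 nM in this assay, at which 1 of the 3 values shown sits, so its true number is unknown. Within the data shown here, the step of an at least 2.8-fold higher number from compound 1 to compound 2 (0.44 log units; beyond the scatter) is the one measured change that bears here. Compound 4 `C=CCc1ccc(OCc2ccc(Cl)c(Cl)c2)c(-c2ccc(O)c(CC=C)c2)c1` differs from compound 2 as follows: hydrogen in place of 3,4-dichlorobenzyl on an oxygen on an aromatic ring. Compound 4, like compound 1, keeps one hydroxy and one (3,4-dichlorobenzyl)oxy group, so the number is expected to fall, by an at least 3.1-fold lower number from compound 2 to compound 4 (0.49 log units; beyond the scatter), back toward that of compound 1. Compound 4 is estimated at 16000 nM, with a range of 6000 nM to 45000 nM.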

Compound 4, half-maximal inhibitory concentration: 14200 nM
Compound 4: middle estimate off by 1.1-fold (0.05 log units), on the high side, and the stated range covers the measured number.
By their numbers in this assay, from the lowest: compounds 3, 4 and 1 (each within the scatter of the next). At a limit, above all of these: compound 2.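

Replacing (3,4-dichlorobenzyl)oxy with hydroxy on this second ring gives an at least 3.5-fold lower number from compound 2 to compound 4 (0.54 log units; beyond the scatter) in this assay. Together with the earlier step at the other oxygen, this shows that removing either of the two 3,4-dichlorobenzyl groups from compound 2 returns a measurable number. Compound 2 stands at a limit, so this step gives only a lower bound on the change: the limit of > 50000 nM in this assay, at which 1 of the 4 values shown sits.

Still open, going by these compounds, is how a methyl ether or a longer chain ending in an amine would read on this oxygen. Also open, on these data alone, is whether 2,4-dichlorobenzyl on this ring would read like 3,4-dichlorobenzyl.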